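A few compounds are considered here, and "the series" means these few. Any claim that something is new, unique, unknown or untested is made for them only; others in the source may bear on it.

The measured compounds and their values:

compound 1, `CS(=O)(=O)Nc1ccc(Cl)c2c1CCCC2c1c[nH]cn1`: 41%
compound 2, `CS(=O)(=O)Nc1cccc2c1CCCCC2c1c[nH]cn1`: 17%
compound 3, `CS(=O)(=O)Nc1cccc2c1CCCC2C1=NCCN1`: 87%

In a functional assay on Urethra with Alpha-1A adrenergic receptor (Oryctolagus cuniculus) as the target (a lower number here means a smaller maximal response, a higher number a larger maximal response), compound 1 gives 41%, the second highest of the three numbers. Its nearest neighbour is compound 2 with 17%, a number lower by more than the usual scatter. Furthest away is compound 3 with 87%, higher by more than the scatter. No two of the measured compounds differ in only one place, so none of these gaps can be attributed to a single structural change.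

Compound 4, `CS(=O)(=O)Nc1ccc(F)c2c1CCCC2c1c[nH]cn1`, differs from compound 1 as follows: fluoro in place of chloro on an aromatic carbon. Among the compounds with values here, none of the measured compounds shows what such an exchange does in this assay, so the expectation rests on compound 1 alone. The step from compound 1 to compound 4 is expected to be small, a number 5 percentage points higher from compound 1 to compound 4 (within the scatter), with no direction beyond the scatter. Compound 4 is therefore estimated to give 46%, with a range from 26% to 68%.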

Compound 4, largest response reached (reported as efficacy), in percent of the reference or control that the assay uses: 64%
Beside the measured number, compound 4's estimate is 18 percentage points below it; the range from low to high includes it.
By their numbers in this assay, from the lowest: compound 2; then compound 1; then compound 4; then compound 3.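

Within the data shown here, the step of a number 23 percentage points higher from compound 1 to compound 4 (beyond the scatter) in this assay is the first single-place comparison in this set, and it lies beyond the scatter. It shows that the maximal response is sensitive to which halogen sits on this aromatic carbon, para to the methanesulfonamido group, even though the exchange replaces one heavy atom with one heavy atom and leaves the counted donors and acceptors unchanged. No measurement available here accounts for the step.

The compounds shown leave open what an unsubstituted carbon, a methyl group or a methoxy group at this place would give on the core of compound 1, and so whether the halogens fit any wider trend. They also leave open whether fluoro in place of chloro would produce a similar step on the cores of compound 2 or compound 3.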